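Swapping acetylsulfanyl for vinyl on a cytotoxic cyclic peptide

This account rests on a few compounds, and the source may have more. Where it says the series, first, only, none or still open, it means among the compounds named here.

Measured so far in a functional assay on P388 cells (Mus musculus) for cytotoxicity; on this read-out higher numbers stand for weaker inhibition and lower numbers for stronger inhibition
- compound 1 `COC(=O)C[C@@H]1NC(=O)[C@@H](C)NC(=O)[C@@H]2Cc3ccc(OC)c(c3)Oc3ccc(cc3)C[C@@H](C(=O)N2C)N(C)C(=O)[C@H](C)NC(=O)[C@H](Cc2ccc(OC)cc2)N(C)C1=O` gives 41.7 nM
- compound 2 `COc1ccc(C[C@H]2C(=O)N[C@@H](C)C(=O)N(C)[C@H]3Cc4ccc(cc4)Oc4cc(ccc4OC)C[C@@H](C(=O)N[C@H](C)C(=O)N[C@@H](CSC(C)=O)C(=O)N2C)N(C)C3=O)cc1` gives 9.77 nM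
- compound 3 `COc1ccc(C[C@H]2C(=O)N[C@@H](C)C(=O)N(C)[C@H]3Cc4ccc(cc4)Oc4cc(ccc4OC)C[C@@H](C(=O)N[C@H](C)C(=O)NC4(SCCS4)C(=O)N2C)N(C)C3=O)cc1` gives 631 nM

Compound 2 has the lowest number of the three, which here means the strongest inhibition. Compound 1 and compound 3 both lie higher, beyond the scatter. The next analogue is compound 4 `C=CC[C@@H]1NC(=O)[C@@H](C)NC(=O)[C@@H]2Cc3ccc(OC)c(c3)Oc3ccc(cc3)C[C@@H](C(=O)N2C)N(C)C(=O)[C@H](C)NC(=O)[C@H](Cc2ccc(OC)cc2)N(C)C1=O`, and its change is counted as follows (vinyl in place of acetylsulfanyl on a saturated chain carbon bound to a saturated ring carbon).

Within the data shown here, the one measured step at this place, with acetylsulfanyl replacing methoxycarbonyl, is a 4.3-fold lower number from compound 1 to compound 2 (0.63 log units; beyond the scatter) and it is modest. Among the measured compounds shown here, no measured compound carries vinyl here, so any forecast is loose. With acetylsulfanyl gone, compound 4 may drift back towards compound 1 (41.7 nM) in this assay and so show a higher number. The expected change is a 3.1-fold higher number from compound 2 to compound 4 (0.49 log units; beyond the scatter) and it is again modest. Compound 4 is estimated at 30 nM (range 8 nM to 120 nM).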

Compound 4, half-maximal inhibitory concentration: 38.9 nM
Compound 4: middle estimate off by 1.3-fold (0.11 log units), on the low side; measured number inside the range.
By their numbers in this assay, from the lowest: compound 2; then compounds 4 and 1 (each within the scatter of the next); then compound 3.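

Replacing acetylsulfanyl with vinyl in this assay gives a 4.0-fold higher number from compound 2 to compound 4 (0.60 log units; beyond the scatter) and so removes the advantage seen for compound 2. Vinyl and methoxycarbonyl cannot be told apart at this place, since a 1.1-fold lower number from compound 1 to compound 4 (0.03 log units; within the scatter) lies within the scatter, which leaves acetylsulfanyl as the only one of these three groups that stands out in this series. No available evidence accounts for this difference.

The compounds shown leave open whether the lower number depends on the sulfur or on the acetyl part of acetylsulfanyl, which a free thiol or a simple methylsulfanyl group at this place could help separate. They also leave open how an amine, a carboxylic acid or a longer chain on this saturated chain carbon would read in this assay and whether any of these would match compound 2.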